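Amide chain variation: isopentyl to phenethyl

The source may report more compounds than this note shows. Statements on the series, on what has been measured and on what is new or still open speak of the compounds shown alone.

Measured so far in an assay on LtK cells with ATP-sensitive inward rectifier potassium channel 11 (Homo sapiens) as the target; a higher number here means that more compound is needed for the effect, a lower number that less compound is needed:
compound 1, `C/C=C/C(=O)Nc1c(C(O)(C(F)(F)F)C(F)(F)F)ccc2ccccc12`: 72 nM
compound 2, `CCCC(C)C(=O)Nc1c(C(O)(C(F)(F)F)C(F)(F)F)ccc2ccccc12`: > 10000 nM (a limit of this assay)
compound 3, `CC(C)CCC(=O)Nc1c(C(O)(C(F)(F)F)C(F)(F)F)ccc2ccccc12`: 49 nM

Compound 3 holds the lowest of the two real numbers, but compound 1 sits within the scatter of it (a 1.5-fold lower number from compound 1 to compound 3 (0.17 log units; within the scatter)), so no order between the two is claimed. The value of compound 2 is a limit of this assay only. Compound 4, `O=C(CCc1ccccc1)Nc1c(C(O)(C(F)(F)F)C(F)(F)F)ccc2ccccc12`, differs from compound 3 by phenyl in place of isopropyl on a saturated chain carbon, two bonds along the chain from a carbonyl carbon. Among the measured compounds shown here, two measured steps bear on it: a 1.5-fold lower number from compound 1 to compound 3 (0.17 log units; within the scatter) was within the scatter, while an at least 200-fold lower number from compound 2 to compound 3 (2.30 log units; beyond the scatter) was large, with 1-methylbutyl in place of isopentyl. The change to compound 4 keeps isopentyl's chain and swaps only isopropyl for phenyl, so no step beyond the scatter is expected in this assay. Compound 4 is estimated at 60 nM, range 15 nM to 250 nM, meaning an expected 1.2-fold higher number from compound 3 to compound 4 (0.09 log units; within the scatter).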

Compound 4, half-maximal effective concentration: 1750 nM
For compound 4 the middle estimate is 29-fold (1.46 log units) below the measured one, and the stated range ends below it.
By their numbers in this assay, from the lowest: compounds 3 and 1 (each within the scatter of the next); then compound 4. At a limit, above all of these: compound 2.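

The step of a 36-fold higher number from compound 3 to compound 4 (1.55 log units; beyond the scatter) shows that the chain end, two bonds along the chain from a carbonyl carbon, does not tolerate every group: phenyl in place of isopropyl moves the number well beyond the scatter. Phenethyl also parts from the prop-1-en-1-yl amide, with a 24-fold higher number from compound 1 to compound 4 (1.39 log units; beyond the scatter). With a limit of the assay on one side, an at least 5.7-fold lower number from compound 2 to compound 4 (0.75 log units; beyond the scatter) gives only a bound, and no measurement shown accounts for these steps.

Going by these compounds, whether a cyclohexyl group at this place would behave like phenyl or like isopropyl remains open. So does the effect of a longer chain carrying the phenyl ring.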